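Methyl on the aromatic nitrogen of compound 1

A few compounds are considered here, and "the series" means these few. Any claim that something is new, unique, unknown or untested is made for them only; others in the source may bear on it.

In a functional assay on HCT-116 cells (Homo sapiens) for antiproliferative activity, read by MTT assay, with a stated time of 48 h (a lower number here means a stronger inhibitor, a higher number a weaker inhibitor), compound 1 (`CCOc1cc(-c2ccc3cc[nH]c3c2)cn2c(-c3cc(OC)c(OC)c(OC)c3)nnc12`) gives 1340 nM and compound 2 (`COc1cc(-c2nnc3c(OC(C)C)cc(-c4ccc5[nH]ccc5c4)cn23)cc(OC)c1OC`) gives 939 nM within the scatter of it. Compound 3 (`COc1cc(-c2nnc3c(OC4CC4)cc(-c4ccc5[nH]ccc5c4)cn23)cc(OC)c1OC`) gives 275 nM and lies beyond the scatter of compound 1 on the lower side. Compound 4 (`CCOc1cc(-c2ccc3ccn(C)c3c2)cn2c(-c3cc(OC)c(OC)c(OC)c3)nnc12`) differs from compound 1 by methyl in place of hydrogen on an aromatic nitrogen. Among the compounds with values here, the only measured step, a 3.4-fold lower number from compound 2 to compound 3 (0.53 log units; beyond the scatter) for cyclopropyl in place of isopropyl on an oxygen, is modest and concerns another place. Within the data shown here, no measured pair tests this nitrogen. On these data alone, no shift beyond the scatter is therefore expected in this assay and the direction remains open. The expected step is a 1.5-fold lower number from compound 1 to compound 4 (0.17 log units; within the scatter) and remains only an estimate. For compound 4 the estimated value is 900 nM within an expected range of 250 nM to 2800 nM for now.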

Compound 4, half-maximal inhibitory concentration: 291 nM
Compound 4: middle estimate off by 3.1-fold (0.49 log units), on the high side, within the range that was stated.
By their numbers in this assay, from the lowest: compounds 3 and 4 (each within the scatter of the next); then compounds 2 and 1 (each within the scatter of the next).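

In this assay methyl in place of hydrogen on the aromatic nitrogen gives a 4.6-fold lower number from compound 1 to compound 4 (0.66 log units; beyond the scatter) and so makes this nitrogen, untested by any earlier pair, a second place in the series where the number responds. The hydrogen on this nitrogen is not needed for activity in compound 4, and the methyl is tolerated here. No measurement at hand gives a reason for the step. On these data alone, whether ethyl or a longer chain ending in an amine on this nitrogen would go further stays open. So does whether methyl here gives a similar step when cyclopropyl sits on the oxygen.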